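The source may hold more compounds than are shown below. What is called first, only, known or untested is meant among the compounds shown, and "the series" means these compounds.

Measured in a functional assay on the whole organism for inhibition, with Felis catus as the target, with a stated time of 30 min; a lower number here means that less compound is needed, a higher number that more compound is needed for the effect:
- Compound 1 `OC(CNCCOc1ccccc1)COc1ccccc1`: 0.054 mg/kg
- Compound 2 `COc1ccccc1OCCNCC(O)COc1ccccc1`: 0.063 mg/kg

Going by the values given here, compound 1 stands level with compound 2, the only other compound measured. Among the compounds with values here, the single measured step is a 1.2-fold higher number from compound 1 to compound 2 (0.07 log units; within the scatter), so adding methoxy made no clear difference. Compound 3 `OC(CNCCOc1ccc(OCc2ccccc2)cc1)COc1ccccc1` has not yet been measured. Its change is benzyloxy in place of hydrogen on an aromatic carbon, which puts benzyloxy in place of hydrogen on an aromatic carbon. The methoxy step is only a weak guide, as no group this large has been measured, so a moderate rise in the number is expected rather than a flat result. The estimated change is a 2.2-fold higher number from compound 1 to compound 3 (0.35 log units; beyond the scatter). For compound 3 the expected value is 0.12 mg/kg, with an estimated range of 0.03 mg/kg to 0.5 mg/kg.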

Compound 3, dose for half-maximal effect: 0.534 mg/kg
The estimate for compound 3 lay 4.5-fold (0.65 log units) below the measured number, and the stated range ends below it.
By their numbers in this assay, from the lowest: compounds 1 and 2 (each within the scatter of the next); then compound 3.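

Benzyloxy on this aromatic carbon, para to a large group, gives a 9.9-fold higher number from compound 1 to compound 3 (1.00 log units; beyond the scatter), so more compound is needed for the effect. This is the first change shown that moves the number beyond the scatter, so this ring carbon does not accept every added group without a loss. Nothing measured here accounts for the rise.

On these data alone, whether a hydroxyl or an ethoxy group on this carbon would stay level with compound 1 remains open. So does the question of whether the added benzene ring or the oxygen linking it matters more for the rise.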